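Swapping a urea cap for a methoxybenzyl arm

This account rests on a few compounds, and the source may have more. Where it says the series, first, only, none or still open, it means among the compounds named here.

Of the compounds shown here, three sharing one core have been measured in an assay on isolated protein for displacement of a labelled ligand from Apoptosis regulator Bcl-2 (Homo sapiens), read by fluorescence polarization; a lower number here means a stronger inhibitor, a higher number a weaker inhibitor. Compound 1 `COc1ccccc1CC1(OC)CCN(c2ccc(C(=O)NS(=O)(=O)c3ccc(N[C@H](CCN(C)C)CSc4ccccc4)c([N+](=O)[O-])c3)cc2)CC1` gives 1.6 nM. Compound 2 `CN(C)CC[C@H](CSc1ccccc1)Nc1ccc(S(=O)(=O)NC(=O)c2ccc(N3CCC4(CC3)CC(c3ccccc3)=NO4)cc2)cc1[N+](=O)[O-]` gives 35.2 nM. Compound 3 `CN(C)CC[C@H](CSc1ccccc1)Nc1ccc(S(=O)(=O)NC(=O)c2ccc(N3CCN(C(=O)Nc4ccccc4)CC3)cc2)cc1[N+](=O)[O-]` gives 300 nM, the highest of the three numbers, and both gaps, to compound 2 and to compound 1, lie beyond the usual scatter, so compound 3 is the weakest inhibitor here.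

Compound 4 `COc1ccccc1CN1CCN(c2ccc(C(=O)NS(=O)(=O)c3ccc(N[C@H](CCN(C)C)CSc4ccccc4)c([N+](=O)[O-])c3)cc2)CC1` differs from compound 3 in one place: 2-methoxybenzyl in place of phenylcarbamoyl on an amine nitrogen in a ring. Within the data shown here, a 2-methoxybenzyl group also appears in compound 1, attached there to a ring carbon rather than to a ring nitrogen, and no measured pair isolates this exact swap.

A step from compound 3 to compound 4 of a 10-fold lower number from compound 3 to compound 4 (1.00 log units; beyond the scatter) is expected, toward a stronger inhibitor, because compound 1 with its own 2-methoxybenzyl group gives 1.6 nM. For compound 4 in this assay the estimate is 30 nM, with a plausible range from 6 nM to 150 nM.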

Compound 4, inhibition constant: 3.2 nM
The estimate for compound 4 lay 9.4-fold (0.97 log units) above the measured number, and the stated range ends above it.
By their numbers in this assay, from the lowest: compounds 1 and 4 (each within the scatter of the next); then compound 2; then compound 3.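

Replacing phenylcarbamoyl with 2-methoxybenzyl on the amine nitrogen in the ring gives a 94-fold lower number from compound 3 to compound 4 (1.97 log units; beyond the scatter) in this assay, toward a stronger inhibitor, so this position responds strongly to the choice of group. The step is large even though the two groups have the same number of heavy atoms, and each carries one six-membered aromatic ring of carbon only and one hydrogen-bond acceptor; phenylcarbamoyl alone has a hydrogen-bond donor, a nitrogen and a double bond outside the ring. No measurement here explains the step.

Still open, as far as these compounds go, is how much of the step belongs to the methoxy group, which a plain benzyl group on the same ring nitrogen would help to show. A phenylacetyl group there would test whether the carbonyl can be tolerated without the amide hydrogen.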